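Moving the fluorine on the benzyl group of compound 2

The compounds below may be only part of what the source reports. "The series", "measured", "known", "first", "only" and "open" are said of these compounds alone.

compound 1 `COc1cccc(C(=O)Oc2ccc3c(=O)c(-c4cc(OC)c(OC)cc4OC)coc3c2)c1` gives > 10000 nM (a limit of the assay)
compound 2 `COc1cc(OC)c(-c2coc3cc(OCc4ccc(F)cc4)ccc3c2=O)cc1OC` gives 1720 nM
compound 3 `COc1cc(OC)c(-c2coc3cc(OCc4ccc(C#N)cc4)ccc3c2=O)cc1OC` gives 1550 nM

In a functional assay on A-375 cells (Homo sapiens) for antiproliferative activity, read by MTT assay, with a stated time of 24 h (on this read-out lower numbers stand for stronger inhibition and higher numbers for weaker inhibition), compound 2 gives 1720 nM. Its nearest measured neighbour lies within the scatter, with a 1.1-fold lower number from compound 2 to compound 3 (0.05 log units; within the scatter). Compound 1 reports only a limit, > 10000 nM.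

Compound 4 `COc1cc(OC)c(-c2coc3cc(OCc4cccc(F)c4)ccc3c2=O)cc1OC` keeps everything in compound 2 except one detail, (3-fluorophenyl in place of 4-fluorophenyl on a saturated chain carbon bound to an oxygen on an aromatic ring). It has 3-fluorophenyl in place of 4-fluorophenyl on a saturated chain carbon bound to an oxygen on an aromatic ring.

Two of the measured steps are the larger ones, an at least 5.8-fold lower number from compound 1 to compound 2 (0.76 log units; beyond the scatter) and an at least 6.4-fold lower number from compound 1 to compound 3 (0.80 log units; beyond the scatter). Both replace the whole (3-methoxyphenyl)carbonyl group, so they bear only loosely on a change this small. The closest guide is the swap of cyano for fluoro on the same ring, and that step stayed within the scatter. Among the measured compounds shown here, no measured step moves a group around this ring, so the expectation rests on that single comparison.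

In this assay no change beyond the scatter is therefore expected, and the expected step is a 1.0-fold lower number from compound 2 to compound 4 (0.01 log units; within the scatter). For compound 4 the estimated value is 1700 nM, with an expected range of 800 nM to 3500 nM.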

Compound 4, half-maximal inhibitory concentration: 1300 nM
Beside the measured number, compound 4's estimate is 1.3-fold (0.12 log units) above it; the range from low to high includes it.
By their numbers in this assay, from the lowest: compounds 4, 3 and 2 (each within the scatter of the next). At a limit, above all of these: compound 1.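

In this assay, among the compounds shown here, this is the first measured move of a group around this ring, and it gives a 1.3-fold lower number from compound 2 to compound 4 (0.12 log units; within the scatter), while the comparison with the 4-cyanophenyl compound gives a 1.2-fold lower number from compound 3 to compound 4 (0.08 log units; within the scatter), so compounds 2, 3 and 4 form a single cluster in which neither the place of the fluorine nor the swap to 4-cyanophenyl separates the values. The step of an at least 7.6-fold lower number from compound 1 to compound 4 (0.88 log units; beyond the scatter) agrees with the two earlier steps away from compound 1, so all three compounds with a substituted benzyl group on this oxygen lie clear of the (3-methoxyphenyl)carbonyl compound. Compound 1 is recorded only at a limit, so the true size of these steps stays unknown: the limit of > 10000 nM in this assay, at which 1 of the 4 values shown sits.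

The compounds shown leave open whether a 2-fluorobenzyl group, or an amine or a carboxylic acid on the same ring, would move the value out of this cluster. They also give no reason for the closeness of these values, and they leave open what a longer chain between the oxygen and the ring would do.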